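The source may hold more compounds than are shown below. What is called first, only, known or untested is meant among the compounds shown, and "the series" means these compounds.

Compound 1 `Fc1cccc(-c2nc(Nc3ccc(Cl)cc3)c3cc(F)ccc3n2)c1` and compound 2 `Oc1ccccc1Nc1nc(-c2cccc(F)c2)nc2ccc(F)cc12` share one core and differ only in the group on the ring nitrogen. In a functional assay on HL-60 cells (Homo sapiens) for cytotoxicity, read by MTT assay, with a stated time of 48 h (on this read-out higher numbers stand for weaker inhibition and lower numbers for stronger inhibition), compound 1 gives 45700 nM, and compound 2 gives 44400 nM; the step of a 1.0-fold lower number from compound 1 to compound 2 (0.01 log units; within the scatter) is within the scatter, so the two numbers cannot be told apart. Compound 2 thus stands at one of two values that sit on top of each other, with compound 1 the only other point.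

Compound 3 `Nc1ccccc1Nc1nc(-c2cccc(F)c2)nc2ccc(F)cc12` carries the change (amino in place of hydroxy on an aromatic carbon), that is, amino in place of hydroxy on an aromatic carbon of the six-membered ring of carbon only, ortho to a large group. For the measured compounds named here, the only measured step, a 1.0-fold lower number from compound 1 to compound 2 (0.01 log units; within the scatter), touched the same ring and moved nothing, which suggests that this ring tolerates such swaps without a shift in this assay. A step of about a 1.0-fold lower number from compound 2 to compound 3 (0.00 log units; within the scatter) is therefore expected, not beyond the scatter. Compound 3 is estimated at 44000 nM, with a likely range from 18000 nM to 100000 nM.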

Compound 3, half-maximal inhibitory concentration: 41300 nM
The estimate for compound 3 lay 1.1-fold (0.03 log units) above the measured number; low and high end bracket the measured number.
By their numbers in this assay, from the lowest: compounds 3, 2 and 1 (each within the scatter of the next).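

In this assay, amino in place of hydroxy on this aromatic carbon, ortho to a large group, gives a 1.1-fold lower number from compound 2 to compound 3 (0.03 log units; within the scatter) and so leaves the number unchanged within the scatter. The comparison with the 4-chlorophenyl compound points the same way, with a 1.1-fold lower number from compound 1 to compound 3 (0.04 log units; within the scatter) for 2-aminophenyl in its place, so the three groups compared on this ring cannot be told apart in this cytotoxicity read-out. No experimental information is available to explain why these compounds read alike.

The compounds shown leave open whether a larger or differently built group on this ring, such as a carboxylic acid or a longer chain, would shift the number beyond the scatter. They also leave open whether amino and hydroxy would still match with other groups elsewhere on the shared core.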